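The source may report more compounds than this note shows. Statements on the series, on what has been measured and on what is new or still open speak of the compounds shown alone.

Working notes on the series in a functional assay with Mus musculus as the target; on this read-out lower numbers stand for an effect already at smaller amounts and higher numbers for an effect only at larger amounts of compound. Compound 3 `Cn1c(=O)n(C2OC(CO)[C@@H](O)[C@H]2O)c2nc(N)nc(O)c21` stands second highest of the three numbers, giving 120 uM; compound 1 `Nc1nc(O)c2c(n1)n(C1OC(CO)[C@@H](O)[C@H]1O)c(=O)n2Cc1ccc([N+](=O)[O-])cc1` gives 50 uM and compound 2 `CN(C)CCCn1c(=O)n(C2OC(CO)[C@@H](O)[C@H]2O)c2nc(N)nc(O)c21` gives 820 uM. The next compound is compound 4 `CCCCCCn1c(=O)n(C2OC(CO)[C@@H](O)[C@H]2O)c2nc(N)nc(O)c21`, whose change from compound 3 is pentyl in place of hydrogen on a saturated chain carbon bound to an aromatic nitrogen. The same position was varied twice: a 2.4-fold higher number from compound 1 to compound 3 (0.38 log units; beyond the scatter), while a 6.8-fold lower number from compound 2 to compound 3 (0.83 log units; beyond the scatter); and a 16-fold higher number from compound 1 to compound 2 (1.21 log units; beyond the scatter). A substituent at this carbon thus moves the number either way, the pentyl group having no donors, acceptors or charge. For compound 4 a modest step downward is expected, a 2.0-fold lower number from compound 3 to compound 4 (0.30 log units; within the scatter). Compound 4 is estimated at 60 uM, within 20 uM to 200 uM.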

Compound 4, concentration for half-maximal effect: 600 uM
Beside the measured number, compound 4's estimate is 10-fold (1.00 log units) below it, outside the stated range (above it).
By their numbers in this assay, from the lowest: compound 1; then compound 3; then compounds 4 and 2 (each within the scatter of the next).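

In this assay, pentyl at this carbon gives a higher number (a 5.0-fold higher number from compound 3 to compound 4 (0.70 log units; beyond the scatter)), so the lower number of compound 1 does not extend to a plain alkyl chain (a 12-fold higher number from compound 1 to compound 4 (1.08 log units; beyond the scatter)). Propyl in place of dimethylamino stays within the scatter (a 1.4-fold lower number from compound 2 to compound 4 (0.14 log units; within the scatter)), so a number this high does not depend on the dimethylamino group. Nothing available explains these steps.

From the compounds shown here alone, whether the lower number of compound 1 goes with its aromatic ring or with its nitro group remains open; benzyl at this carbon would separate the two. Ethyl or a longer chain would show how the number follows chain length.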